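The source may report more compounds than this note shows. Statements on the series, on what has been measured and on what is new or still open speak of the compounds shown alone.

Measured in an assay on CHO cells for displacement of a labelled ligand from adenosine receptor A1 (Homo sapiens); a lower number here means a stronger inhibitor, a higher number a weaker inhibitor:
- compound 1 `COc1ccc(-c2c(C#N)c(N)nc(SCc3nc(-c4ccc(Cl)cc4)sc3Br)c2C#N)cc1`: 162 nM
- compound 2 `COc1ccc(-c2c(C#N)c(N)nc(SCc3nc(-c4ccc(Cl)cc4)sc3Cl)c2C#N)cc1`: 88 nM
- compound 3 `COc1ccc(-c2c(C#N)c(N)nc(SCc3csc(-c4ccc(Br)cc4)n3)c2C#N)cc1`: 3.8 nM

Compound 3 stands lowest of the three numbers in this assay, beyond the scatter from both compound 2 and compound 1. Compound 4 `COc1ccc(-c2c(C#N)c(N)nc(SCc3csc(-c4ccccc4Cl)n3)c2C#N)cc1` differs from it by 2-chlorophenyl in place of 4-bromophenyl on an aromatic carbon. For the measured compounds named here, the only measured step with a halogen change, a 1.8-fold lower number from compound 1 to compound 2 (0.27 log units; within the scatter), concerns a halogen on the five-membered ring, not on the phenyl ring, and moved the number little; no measured pair covers a shift of the halogen from one phenyl position to another. The expectation for compound 4 is therefore a small step, a 3.2-fold higher number from compound 3 to compound 4 (0.50 log units; beyond the scatter), most likely towards a somewhat higher number, with wide uncertainty. Compound 4 is estimated at 12 nM, in the range 3 nM to 50 nM.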

Compound 4, inhibition constant: 11 nM
Compound 4: the middle estimate sits 1.1-fold (0.04 log units) above what was measured; the range from low to high includes it.
By their numbers in this assay, from the lowest: compound 3; then compound 4; then compounds 2 and 1 (each within the scatter of the next).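

In this assay, exchanging 4-bromophenyl for 2-chlorophenyl on this carbon of the five-membered ring gives a modest step beyond the scatter: a 2.9-fold higher number from compound 3 to compound 4 (0.46 log units; beyond the scatter). For the compounds shown here, the earlier compounds held this aryl group constant within each comparison, so this is the first reading of a change to it. The step changes the halogen and its place on the phenyl ring together, and nothing measured here accounts for it.

The compounds shown leave open which of those two changes carries the step. They also leave open how a phenyl ring bearing an amine or a carboxylic acid would read at this carbon.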